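Aromatic substituent swaps on the fused pentacyclic series

The source may hold more compounds than are shown below. What is called first, only, known or untested is meant among the compounds shown, and "the series" means these compounds.

Measured so far:
- compound 1, `COC(=O)[C@@]1(C)CC[C@@H]2C3=C1CC[C@@H](C)[C@]3(C)C[C@@H]1c3cc(C)ccc3N[C@H]21`: 18000 nM
- compound 2, `COC(=O)[C@@]1(C)CC[C@@H]2C3=C1CC[C@@H](C)[C@]3(C)C[C@@H]1c3cc(Cl)ccc3N[C@H]21`: 23000 nM

In a functional assay on HeLa cells (Homo sapiens) for inhibition, read by sulforhodamine B assay, with a stated time of 48 h (on this read-out higher numbers stand for weaker inhibition of growth and lower numbers for stronger inhibition of growth), compound 1 gives 18000 nM and compound 2 gives 23000 nM. Compound 2 stands next to compound 1 only; the step of a 1.3-fold higher number from compound 1 to compound 2 (0.11 log units; within the scatter) does not separate the two, so chloro and methyl on the aromatic carbon read as equivalent here.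

Compound 3, `COC(=O)[C@@]1(C)CC[C@@H]2C3=C1CC[C@@H](C)[C@]3(C)C[C@@H]1c3cc(F)ccc3N[C@H]21`, is not yet measured in this assay. It differs from compound 2 by fluoro in place of chloro on an aromatic carbon. Among the compounds with values here, the only step that bears on this exchange is a 1.3-fold higher number from compound 1 to compound 2 (0.11 log units; within the scatter), where replacing methyl by chloro at the same aromatic carbon moved the number within the scatter. Within the data shown here, no step involving fluoro is available, so the expectation rests on the one halogen exchange seen.

For compound 3 a step of a 1.2-fold lower number from compound 2 to compound 3 (0.06 log units; within the scatter) is expected, that is, no change beyond the scatter. Compound 3 is therefore estimated at 20000 nM, with a range from 8000 nM to 50000 nM.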

Compound 3, concentration for 50% growth inhibition: 20000 nM
Estimate against measurement, compound 3: no gap at the digits printed, and the stated range covers the measured number.
By their numbers in this assay, from the lowest: compounds 1, 3 and 2 (each within the scatter of the next).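

In this assay, fluoro in place of chloro on the aromatic carbon gives a 1.2-fold lower number from compound 2 to compound 3 (0.06 log units; within the scatter), and fluoro in place of methyl gives a 1.1-fold higher number from compound 1 to compound 3 (0.05 log units; within the scatter). With fluoro added, all three exchanges among methyl, chloro and fluoro at this carbon stay within the scatter, so the earlier single comparison now extends to a second halogen and the number does not separate any of the three groups. No measured information on the compounds bears on why these groups read alike.

On these data alone, whether an amine, a carboxylic acid or a longer chain on this aromatic carbon would move the number beyond the scatter remains open. Also open, as far as these compounds go, is whether a hydrogen at this carbon reads like these three groups, and whether exchanging the methyl ester elsewhere on the shared core for a carboxylic acid changes the number.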